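Amino in place of hydroxy on the base of compound 2

The source may report more compounds than this note shows. Statements on the series, on what has been measured and on what is new or still open speak of the compounds shown alone.

Measured in a functional assay on HeLa cells (Homo sapiens); a lower number here means a stronger inhibitor, a higher number a weaker inhibitor:
Compound 1, `N#C[C@]1(O)[C@H](O)[C@@H](CO)O[C@@H](n2cc(F)c(O)nc2=O)[C@@H]1O`: 4500 nM
Compound 2, `N#C[C@]1(O)[C@H](O)[C@@H](CO)O[C@@H](n2ccc(O)nc2=O)[C@@H]1O`: > 500000 nM
Compound 3, `Cc1cn([C@@H]2O[C@H](CO)[C@@H](O)[C@@](O)(C#N)[C@H]2O)c(=O)nc1O`: > 500000 nM

Compound 2 stands only at a limit of this assay, since > 500000 nM is the ceiling of the measurement and not a number. As the limit of > 500000 nM in this assay, at which 2 of the 3 values shown sit, two of the three compounds sit there. Compound 4, `N#C[C@]1(O)[C@H](O)[C@@H](CO)O[C@@H](n2ccc(N)nc2=O)[C@@H]1O`, differs from compound 2 by amino in place of hydroxy on an aromatic carbon. Among the measured compounds shown here, no measured step touches this change: an at least 110-fold higher number from compound 1 to compound 2 (2.04 log units; beyond the scatter) and an at least 110-fold higher number from compound 1 to compound 3 (2.04 log units; beyond the scatter) concern another aromatic carbon, and a step that the two limits leave unreadable from compound 2 to compound 3. The size and direction of the step from compound 2 thus cannot be read from the numbers shown, and the estimate stays wide. Compound 4 is expected at 100000 nM, within 3000 nM to 500000 nM. The expected step is an at least 5.0-fold lower number from compound 2 to compound 4 (0.69 log units; beyond the scatter).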

Compound 4, half-maximal inhibitory concentration: 377000 nM
Compound 4: middle estimate off by 3.8-fold (0.58 log units), on the low side; the measured number falls inside the stated range.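

In this assay, amino in place of hydroxy gives an at least 1.3-fold lower number from compound 2 to compound 4 (0.12 log units; that floor lies within the scatter) and is the only change at this position among the compounds shown. Compound 4 carries a true number, but the floor of this step does not establish a real gain over hydroxy, since compound 2 holds only a limit: the limit of > 500000 nM in this assay, at which 2 of the 4 values shown sit.

On these data alone, it remains open whether amino would behave the same way on the fluoro-bearing base of compound 1. As far as these compounds go, how a methylamino or methoxy group would read at this position also remains open.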